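This account rests on a few compounds, and the source may have more. Where it says the series, first, only, none or still open, it means among the compounds named here.

Measured compounds:
compound 1, `COc1cc(/C=C2\C(=O)Nc3ccc(Cl)cc32)ccc1OCCCN1CC(C)OC(C)C1`, 2710 nM in a functional assay on DU-145 cells (Homo sapiens) for cytotoxicity, read by MTT assay, with a stated time of 48 h; a lower number here means a stronger inhibitor, a higher number a weaker inhibitor
compound 2, `COc1cc(/C=C2\C(=O)Nc3ccc(C)cc32)ccc1OCCCN1CC(C)OC(C)C1`, > 20000 nM
compound 3, `COc1cc(/C=C2\C(=O)Nc3ccc(Cl)cc32)ccc1OCCCN1CCN(c2ncccc2C(F)(F)F)CC1`, 1610 nM

The three measured compounds share a core that carries either a chloro or a methyl group, and a side chain that ends in one of two amines. Compound 1 and compound 3 carry the chloro group and differ in the amine; the difference between the two cores is not broken down here. In this assay compound 3 gives 1610 nM, and compound 1 gives 2710 nM, two values that lie within the scatter of each other.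

Going by the values given here, compound 2 is the first methyl analogue. Its result in this assay is a limit of the assay, not a number: > 20000 nM, which is the limit of > 20000 nM in this assay, at which 1 of the 3 values shown sits. The change from compound 1 to compound 2 is methyl in place of chloro on an aromatic carbon, and it produced an at least 7.3-fold higher number from compound 1 to compound 2 (0.86 log units; beyond the scatter).

Compound 4, `COc1cc(/C=C2\C(=O)Nc3ccc(C)cc32)ccc1OCCCN1CCN(c2ncccc2C(F)(F)F)CC1`, has not yet been measured. It is related to compound 3 by methyl in place of chloro on an aromatic carbon, the same change as that from compound 1 to compound 2, at the same place on the core. Resting on an at least 7.3-fold higher number from compound 1 to compound 2 (0.86 log units; beyond the scatter), the expected step is a 9.3-fold higher number from compound 3 to compound 4 (0.97 log units; beyond the scatter), and it is also expected that the result for compound 4 may again come back as a limit rather than a number. Compound 4 is estimated to give 15000 nM in this assay, with a likely range from 6000 nM to 40000 nM.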

Compound 4, half-maximal inhibitory concentration: > 20000 nM
Compound 4 was reported as a limit (the forecaster's own chance of this, stated with the estimate: 55%); middle value at least 1.3-fold (0.12 log units) away from the limit.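

In this assay compound 4 gives > 20000 nM, which is a limit of the assay and not a number, and the four compounds now hold two such results: the limit of > 20000 nM in this assay, at which 2 of the 4 values shown sit. With the amine of compound 3, methyl in place of chloro on an aromatic carbon gave an at least 12-fold higher number from compound 3 to compound 4 (1.09 log units; beyond the scatter), so the change that weakened compound 1 also weakened a compound with a different amine, and on both cores the step lies beyond the scatter. This shows that the direction of the change carried over between these two chloro compounds, but it does not show that the size of the step carried over, since neither methyl compound gives a number and the two steps can only be set side by side: the same change on two cores in this assay, an at least 7.3-fold higher number (0.86 log units; beyond the scatter) from compound 1 to compound 2 and an at least 12-fold higher number (1.09 log units; beyond the scatter) from compound 3 to compound 4; the limit leaves it open whether they differ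

The compounds shown leave open how other groups would behave at this place on the core, such as a fluoro, a bromo or a methoxy group, and so whether chloro is unusual or methyl is simply poor there. They also leave open whether the same result would hold with a different amine, such as a piperidine, or with a longer chain.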